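Cytotoxicity limits of a benzothiadiazine series in liver cells

The compounds below may be only part of what the source reports. "The series", "measured", "known", "first", "only" and "open" are said of these compounds alone.

Measured compounds:
- compound 1, `CN1C(=O)C(C2=NS(=O)(=O)c3cc(NS(C)(=O)=O)ccc3N2)=C(O)C2CCCC21`: "not determined" (no result reported)
- compound 2, `CS(=O)(=O)Nc1ccc2c(c1)S(=O)(=O)N=C(C1=C(O)C3CCCC3N(Cc3ccc(F)cn3)C1=O)N2`: > 33000 nM
- compound 3, `Cc1cc(CN2C(=O)C(C3=NS(=O)(=O)c4cc(NS(C)(=O)=O)ccc4N3)=C(O)[C@H]3CCC[C@H]32)ccc1F`: > 1000 nM

Of the compounds shown here, three share one core and have been tested in an ADME assay on Huh-7 cells (Homo sapiens) for cytotoxicity, with a stated time of 72 h; a lower number here means that less compound is tolerated, a higher number that more compound is tolerated. For compound 1 no result was reported in this assay, so it gives "not determined" (no result reported). For compound 2 only a limit was reached: in this assay compound 2 gives > 33000 nM, which is a limit of the assay and not a number. Compound 3 likewise reaches only a limit in this assay, > 1000 nM, so nothing more than a bound is known for it; it stands at the limit of > 1000 nM in this assay, at which 1 of the 3 values shown sits, while compound 2 stands at the limit of > 33000 nM in this assay, at which 1 of the 3 values shown sits. For the measured compounds named here, no step between two measured compounds can be computed here.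

Compound 4, `CS(=O)(=O)Nc1ccc2c(c1)S(=O)(=O)N=C(C1=C(O)[C@H]3CCC[C@H]3N(Cc3cccc(C(F)(F)F)c3)C1=O)N2`, has not yet been measured. It differs from compound 3 in one place: 3-(trifluoromethyl)phenyl in place of 4-fluoro-3-methylphenyl on a saturated chain carbon bound to an amide-type nitrogen in a ring. The 4-fluoro-3-methylphenyl leaves and a 3-(trifluoromethyl)phenyl enters.

Going by the values given here, with only limits known, no step in this assay beyond the scatter is expected, and the expected step is a step that the limit leaves unreadable from compound 3 to compound 4. Compound 4 is therefore estimated to give 20000 nM in this assay, with an expected range from 3000 nM to 100000 nM, quite possibly reported again only as a limit.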

Compound 4, half-maximal cytotoxic concentration: > 33000 nM
Compound 4: no number, only a limit; the forecaster's own chance of this, stated with the estimate: 75%; at least 1.6-fold (0.21 log units) between middle value and limit.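

For the compounds shown here, compound 3 and compound 4 each reach only a limit in this assay, and no step between them can be read. The compounds shown leave open at what concentration any of them becomes toxic to these cells, and whether exchanging 4-fluoro-3-methylphenyl for 3-(trifluoromethyl)phenyl alters it.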